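The compounds below may be only part of what the source reports. "The series", "measured", "known", "first", "only" and "open" are said of these compounds alone.

In a functional assay for inhibition, with a stated time of 2 h (a lower number here means that less compound is needed, a higher number that more compound is needed for the effect), compound 1 (`Cc1sc2c(Nc3cccnc3)cccc2c1C`) gives 17.3 ug/mL and compound 2 (`COc1ccc(Nc2cccc3c(C)c(C)sc23)cc1OC`) gives 8.73 ug/mL and these two values lie within the scatter of each other. The change from compound 1 to compound 3 (`Cc1sc2c(Nc3ccccn3)cccc2c1C`) is pyridin-2-yl in place of pyridin-3-yl on a nitrogen on an aromatic ring with the same atoms joined differently. Among the measured compounds shown here, the series offers no measured step that differs in one place, so no shift beyond the scatter is expected in this assay and the estimated step is a 1.2-fold lower number from compound 1 to compound 3 (0.06 log units; within the scatter) at the middle of the estimate. Compound 3 is estimated at 15 ug/mL with an expected range from 6 ug/mL to 40 ug/mL for now.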

Compound 3, half-maximal effective concentration: > 250 ug/mL
Compound 3 gave a limit, no number; the forecaster's own chance of this, stated with the estimate: 10%; middle value at least 16-fold (1.22 log units) from the limit.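

Pyridin-2-yl in place of pyridin-3-yl on a nitrogen on an aromatic ring is the first change in this series that differs in one place, and in this assay it gives an at least 14-fold higher number from compound 1 to compound 3 (1.15 log units; beyond the scatter). Same atoms joined differently are therefore enough to move this position beyond the scatter. The reading for compound 3 is a limit and not a number: the limit of > 250 ug/mL in this assay, at which 1 of the 3 values shown sits.

The full size of the step stays open, as does any cause for it. Also open, on these data alone, is whether pyridin-4-yl or plain phenyl on this nitrogen reads like pyridin-3-yl or like pyridin-2-yl.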